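This account rests on a few compounds, and the source may have more. Where it says the series, first, only, none or still open, it means among the compounds named here.

- Compound 1 `Cc1ccc(S(=O)(=O)Oc2ccccc2/C=C(\C#N)C(=O)Nc2nnc(C)s2)cc1`: 33%
- Compound 2 `COc1ccc(S(=O)(=O)Oc2ccccc2/C=C(\C#N)C(=O)Nc2nnc(-c3cccs3)s2)cc1`: 76%

Among the measured compounds shown here, in a functional assay on RS4-11 cells (Homo sapiens) for inhibition, read by CCK-8 assay, with a stated time of 48 h, tested at 20 uM (on this read-out lower numbers stand for less inhibition of growth and higher numbers for more inhibition of growth at the one concentration tested), compound 2 is the higher of the two compounds measured so far, at 76%, while compound 1 gives 33%. That gap lies beyond the usual scatter. However, these two compounds differ in more than one place, so their values cannot be tied to any single structural change.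

Compound 3 `N#C/C(=C\c1ccccc1OS(=O)(=O)c1ccc([N+](=O)[O-])cc1)C(=O)Nc1nnc(-c2cccs2)s1` keeps the structure of compound 2 apart from one substitution: nitro in place of methoxy on an aromatic carbon. Nitro takes the place of methoxy on an aromatic carbon, para to a large group. For the measured compounds named here, no measured pair shows this change, so the data offer no direct guide to its size or direction.

The best starting point is therefore compound 2 at 76%, with a small downward step expected in this assay, one that stays within the scatter. The expected change is a number 6 percentage points lower from compound 2 to compound 3 (within the scatter). The estimated value for compound 3 is 70%, with an expected range of 50% to 88%.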

Compound 3, percent growth inhibition at one concentration: 40%
The estimate for compound 3 lay 30 percentage points above the measured number; measured number outside the range, below it.
By their numbers in this assay, from the lowest: compounds 1 and 3 (each within the scatter of the next); then compound 2.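

Among the compounds shown here, this is the first pair of compounds that differ in only one place, so a change in activity can finally be tied to a single swap. In this assay, replacing methoxy with nitro on an aromatic carbon, para to a large group, gives a number 36 percentage points lower from compound 2 to compound 3 (beyond the scatter), so what sits at this position clearly matters for growth inhibition at the one concentration tested. Nothing measured here explains why this swap has such a large effect.

A single swap cannot show whether the methoxy of compound 2 helps or the nitro of compound 3 hurts, and an amine or a plain hydrogen on the same aromatic carbon, with the rest of compound 2 unchanged, would help separate these two readings. As far as these compounds go, it also remains open whether the swap would have an effect of similar size on a different parent structure, such as that of compound 1, which differs from compound 2 in more than one place.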